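Piperidine amide reversal in a chlorophenoxyacetamide series

The compounds below may be only part of what the source reports. "The series", "measured", "known", "first", "only" and "open" are said of these compounds alone.

Working notes on a functional assay on CHO-K1 cells for antagonist activity at melanin-concentrating hormone receptor 1 (Homo sapiens), read by inositol phosphate accumulation; on this read-out lower numbers stand for stronger inhibition and higher numbers for weaker inhibition. Compound 1 `Cc1nc(N2CCN(S(C)(=O)=O)CC2)nc2ccc(NC(=O)COc3ccc(Cl)cc3)cc12` returns only a limit, > 10000 nM, which is the limit of > 10000 nM in this assay, at which 1 of the 3 values shown sits. Compound 2 `Cc1nc(N2CCC(NC(=O)C(C)C)CC2)nc2ccc(NC(=O)COc3ccc(Cl)cc3)cc12` gives 54 nM, the lowest of the two measured numbers. Compound 3 `Cc1nc(N2CCC(N3CCCC3)CC2)nc2ccc(NC(=O)C(C)Oc3ccc(Cl)cc3)cc12` gives 401 nM, a number higher than that of compound 2 by more than the scatter; the two differ in more than one place, so no single step can be read from them. Compound 4 `Cc1nc(N2CCC(C(=O)NC(C)C)CC2)nc2ccc(NC(=O)COc3ccc(Cl)cc3)cc12` is not yet measured; it differs from compound 2 by isopropylcarbamoyl in place of (isopropylcarbonyl)amino on a saturated ring carbon. Among the measured compounds shown here, no measured pair shows this reversal of the amide. The step from compound 2 to compound 4 is expected to be small, toward a weaker number, a 2.0-fold higher number from compound 2 to compound 4 (0.31 log units; beyond the scatter). Compound 4 is expected to give 110 nM, between 25 nM and 500 nM.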

Compound 4, half-maximal inhibitory concentration in the melanin-concentrating hormone receptor 1 assay: 25 nM
Compound 4: middle estimate off by 4.4-fold (0.64 log units), on the high side, within the range that was stated.
By their numbers in the melanin-concentrating hormone receptor 1 assay, from the lowest: compound 4; then compound 2; then compound 3. At a limit, above all of these: compound 1.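

Reversing the amide at this saturated ring carbon, with isopropylcarbamoyl replacing (isopropylcarbonyl)amino, strengthens inhibition in the melanin-concentrating hormone receptor 1 assay: the step is a 2.2-fold lower number from compound 2 to compound 4 (0.33 log units; beyond the scatter). In the melanin-concentrating hormone receptor 1 assay compound 2 gives 54 nM and compound 4 gives 25 nM. In a physicochemical assay for solubility, in phosphate buffer (on this read-out lower numbers stand for lower solubility and higher numbers for higher solubility), compound 2 gives 205000 nM and compound 4 gives 132000 nM. In the physicochemical assay the same change gives a 1.6-fold lower number from compound 2 to compound 4 (0.19 log units; within the scatter), so only the inhibition read-out separates the two orientations. Nothing measured here bears on the cause of either step.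

The compounds shown leave open whether an amide is needed on this ring carbon at all. A carboxylic acid, a primary amine or a cyclopropylcarbamoyl group there could answer that.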